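Series notes: fluoro substitution on the benzyl arm

The source may report more compounds than this note shows. Statements on the series, on what has been measured and on what is new or still open speak of the compounds shown alone.

Measured so far:
compound 1 `CCS(=O)(=O)c1nnc(COc2cc(C)c3c(C)cc(=O)oc3c2)o1`
compound 2 `CCCS(=O)(=O)c1nnc(COc2cc(C)c3c(C)cc(=O)oc3c2)o1`
compound 3 `Cc1cc(OCc2nnc(S(=O)(=O)Cc3ccccc3)o2)cc2oc(=O)cc(C)c12`

In a functional assay on MCF7 cells (Homo sapiens) for antiproliferative activity, read by MTT assay, with a stated time of 24 h (on this read-out lower numbers stand for stronger inhibition and higher numbers for weaker inhibition), compound 1 gives > 100000 nM, which is a limit of the assay and not a number. Compound 2 gives > 100000 nM, again a limit. Going by the values given here, compound 3 gives 38600 nM, the only number among the three values shown; the other two sit at the limit of > 100000 nM in this assay, at which 2 of the 3 values shown sit. Between compound 1 and compound 2 the step is a step that the two limits leave unreadable from compound 1 to compound 2. Going to the benzyl group on the carbon bound to the sulfonyl sulfur gives an at least 2.5-fold lower number from compound 1 to compound 3 (0.41 log units; beyond the scatter) and an at least 2.5-fold lower number from compound 2 to compound 3 (0.41 log units; beyond the scatter), so compound 3 is the reference point of the set.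

Compound 4 `Cc1cc(OCc2nnc(S(=O)(=O)Cc3cccc(F)c3)o2)cc2oc(=O)cc(C)c12` differs from compound 3 by fluoro in place of hydrogen on an aromatic carbon. Among the compounds with values here, none of the measured steps touches this position; all three concern the group on the carbon bound to the sulfonyl sulfur, which compound 4 keeps as benzyl. Within the data shown here, no measured step therefore bears directly on the change, and the expectation for compound 4 is a step of a 1.2-fold lower number from compound 3 to compound 4 (0.08 log units; within the scatter), within the scatter. Compound 4 is estimated at 32000 nM, with a range from 10000 nM to 100000 nM.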

Compound 4, half-maximal inhibitory concentration: 70400 nM
The estimate for compound 4 lay 2.2-fold (0.34 log units) below the measured number; the range from low to high includes it.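

In this assay, going by these compounds alone, this is the first change on the aromatic ring of the benzyl arm, and it gives a 1.8-fold higher number from compound 3 to compound 4 (0.26 log units; within the scatter), so 3-fluorobenzyl in place of benzyl cannot be told apart from compound 3 on this read-out. Against the two alkyl sulfones, the result is an at least 1.4-fold lower number from compound 2 to compound 4 (0.15 log units; that floor lies within the scatter) and an at least 1.4-fold lower number from compound 1 to compound 4 (0.15 log units; that floor lies within the scatter), so these floors lie within the scatter, whereas the floors for compound 3 lie beyond it, and compound 4 does not clearly stand apart from either alkyl sulfone. Both floors are set by limits of the assay and not by numbers: the limit of > 100000 nM in this assay, at which 2 of the 4 values shown sit.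

The compounds shown leave open whether fluoro on another carbon of this ring reads differently, and whether chloro, methoxy or trifluoromethyl at the same place would move the number beyond the scatter from compound 3. They also leave open what a longer chain between the sulfonyl sulfur and the phenyl ring, or an amine on that ring, would do in this assay.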